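Swapping a trifluoromethoxy for a dimethylamino on compound 1

The source may hold more compounds than are shown below. What is called first, only, known or untested is meant among the compounds shown, and "the series" means these compounds.

Compound 1 `O=C(c1cccc(OC(F)(F)F)c1)N1CCC(N(C2CC2)S(=O)(=O)c2cccc(C(F)(F)F)c2)CC1` carries a 3-(trifluoromethoxy)phenyl on the carbonyl carbon of its amide. Among the compounds with values here, in an assay on cells for inhibition of Voltage-dependent L-type calcium channel subunit alpha-1C (Homo sapiens), read by FLIPR and calcium flux, tested at 1 uM (a lower number here means a weaker effect, a higher number a stronger effect of the compound at the concentration tested), compound 1 gives 60%, the lowest of the two numbers reported in this assay; the one neighbour, compound 2 `O=C(c1ccc(OC(F)(F)F)cc1)N1CCC(N(C2CC2)S(=O)(=O)c2cccc(C(F)(F)F)c2)CC1`, gives 73% in this assay, and the only measured step, a number 13 percentage points higher from compound 1 to compound 2 (beyond the scatter), is a positional move of the trifluoromethoxy on the ring. Compound 3 `CS(=O)(=O)c1cccc(C(=O)N2CCC(N(C3CC3)S(=O)(=O)c3cccc(C(F)(F)F)c3)CC2)c1` was entered in this assay but its result is "not determined" (no result reported), so it contributes nothing to the numbers. Compound 4 `CN(C)c1cccc(C(=O)N2CCC(N(C3CC3)S(=O)(=O)c3cccc(C(F)(F)F)c3)CC2)c1` differs from compound 1 in one place: dimethylamino in place of trifluoromethoxy on an aromatic carbon. No measured step exchanges one group for another on that ring, so nothing shown bears directly on this change; the positional step from compound 1 to compound 2 shows only that the ring tolerates modest movement of a group of this kind. With no guide to a replacement of the group itself, compound 4 is expected to land near compound 1 or somewhat lower, and the step of a number 10 percentage points lower from compound 1 to compound 4 (within the scatter) is an estimate that stays within a broad band. Compound 4 is therefore estimated at 50% in this assay, with a range from 25% to 75%.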

Compound 4, a percentage reported as inhibition, at one concentration (the size of the read-out at that concentration, not a potency): 40%
Estimate against measurement, compound 4: 10 percentage points above; measured number inside the range.
By their numbers in this assay, from the lowest: compound 4; then compound 1; then compound 2.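

In this assay, the exchange of the group itself gives a number 20 percentage points lower from compound 1 to compound 4 (beyond the scatter), so the read-out at this place on the ring depends on which group is present and not only on where a group sits. The step of a number 33 percentage points lower from compound 2 to compound 4 (beyond the scatter), which changes both the group and its place on the ring, is large, and it sets the two trifluoromethoxy compounds apart from the dimethylamino compound by a clear margin in this small set. Nothing given here accounts for the lower number with dimethylamino.

The compounds shown leave open whether dimethylamino would respond to a move around the ring in the same direction as trifluoromethoxy, since the only positional step belongs to trifluoromethoxy. They also leave open how other groups in this place, such as a methoxy, a carboxylic acid or a longer amine chain, would compare with the two groups whose numbers can be read here.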